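Three Sulfonamides at the Limit, and a Fourth to Test

This account rests on a few compounds, and the source may have more. Where it says the series, first, only, none or still open, it means among the compounds named here.

Measured so far in an assay on isolated protein for inhibition of malate dehydrogenase, mitochondrial (Sus scrofa), with stated times of 45 min and 30 min; a lower number here means a stronger inhibitor, a higher number a weaker inhibitor:
Compound 1 `Cc1ccccc1S(=O)(=O)Nc1ccc2oc(-c3ccccc3)nc2c1` gives > 63000 nM, which is a limit of the assay and not a number.
Compound 2 `O=S(=O)(Nc1ccc(-c2nc3ccccc3o2)cc1)c1ccccc1C(F)(F)F` gives > 63000 nM, again a limit of the assay.
Compound 3 `Cc1ccccc1S(=O)(=O)Nc1ccc(-c2nc3ccccc3o2)cc1` gives > 63000 nM, likewise a limit of the assay.

Compound 1 therefore stands nowhere in particular on the scale: the assay reports only that its half-maximal inhibitory concentration lies beyond the limit, as it does for the other two compounds, and the limit of > 63000 nM in this assay, at which 3 of the 3 values shown sit, records that every value seen so far sits at that limit.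

For the measured compounds named here, the one step among the measured compounds, a step that the two limits leave unreadable from compound 2 to compound 3, touches a different part of the molecule than the change studied here and, with both ends at the limit, reveals no size at all.

Compound 4 `CCc1ccc(S(=O)(=O)Nc2ccc3oc(-c4ccccc4)nc3c2)cc1` differs from compound 1 in one place, (4-ethylphenyl in place of 2-methylphenyl on a sulfonyl sulfur). Going by the values given here, no measured step shows what swapping one such group for another on the sulfonyl sulfur does, so there is nothing to read an expected direction from, only the fact that every neighbour of compound 4 has failed to register. Compound 4 is expected to behave the same way, with an estimated value of 100000 nM, most likely between 30000 nM and 400000 nM. The step this estimate implies, a step that the limit leaves unreadable from compound 1 to compound 4, is expected to be nothing beyond the scatter.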

Compound 4, half-maximal inhibitory concentration: > 63000 nM
Compound 4: only a limit was reported; the forecaster's own chance of this, stated with the estimate: 85%; the middle value lies beyond the limit too.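

The step between compound 1 and compound 4 cannot be read, since each gives only a limit and not a number, and the same holds across the whole set: the limit of > 63000 nM in this assay, at which 4 of the 4 values shown sit.

The compounds shown leave open how strongly any of them inhibits in this assay, and whether any other group on the sulfonyl sulfur would give a readable value.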